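The source may report more compounds than this note shows. Statements on the series, on what has been measured and on what is new or still open speak of the compounds shown alone.

Three compounds of the series carry numbers in an ADME assay on a cell-free system (plasma, Homo sapiens) for metabolic stability, read by HPLC; on this read-out higher numbers stand for a longer-lived compound and lower numbers for a shorter-lived compound. Compound 1 `CC(=O)c1ccc(/N=N/N(C)C(=O)CCCCc2ccc(O)cc2)cc1` gives 32.7 h in this assay. Compound 2 `COC(=O)c1ccc(/N=N/N(C)C(=O)CCc2cccc(O)c2)cc1` gives 7.8 h, and compound 3 `COC(=O)c1ccc(/N=N/N(C)C(=O)CCc2ccc(O)cc2)cc1` gives 7.3 h. For the measured compounds named here, the single step between measured compounds that differ in one place, a 1.1-fold lower number from compound 2 to compound 3 (0.03 log units; within the scatter), moves the half-life no further than repeated measurements would. Compound 1 holds the highest of the three numbers, and its gap to compound 2 as well as to compound 3 lies beyond the scatter.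

Compound 4 `CN(/N=N/c1ccc(C(N)=O)cc1)C(=O)CCCCc1ccc(O)cc1` is not yet measured. Against compound 1 the change is amino in place of methyl on a carbonyl carbon; cut one bond further out it reads acetyl to carbamoyl. Going by the values given here, no measured step touches this place: the only step in hand concerns the hydroxyphenyl on the saturated chain carbon, and nothing probes the carbonyl carbon attached to the aromatic carbon. The size of the step for compound 4 therefore cannot be read from the series, and the expectation is for no change beyond the scatter. Compound 4 is expected to give about 30 h, within a range of 15 h to 60 h. The step this estimate means, a 1.1-fold lower number from compound 1 to compound 4 (0.04 log units; within the scatter), is expected to stay inside the usual scatter.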

Compound 4, half-life: 55.4 h
Beside the measured number, compound 4's estimate is 1.8-fold (0.27 log units) below it; the measured number falls inside the stated range.
By their numbers in this assay, from the lowest: compounds 3 and 2 (each within the scatter of the next); then compounds 1 and 4 (each within the scatter of the next).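

For the compounds shown here, on the carbonyl carbon whose other neighbour is an aromatic carbon, the earlier compounds offered no step; in this assay amino in place of methyl gives a 1.7-fold higher number from compound 1 to compound 4 (0.23 log units; within the scatter) and so offers the first reading at this place. Acetyl to carbamoyl, which brings in a hydrogen-bond donor absent from the methyl, therefore leaves the half-life of this pair inside the usual scatter. Nothing shown explains this outcome at the level of mechanism.

From the compounds shown here alone, whether a carboxylic acid or a methylamino group on the same carbonyl carbon would also stay within the scatter remains open. Compound 1 and compound 3 differ both at this carbonyl carbon and in the chain, so the separate contribution of each place to their gap cannot be read.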